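Hydroxy in place of bromo: compound 1 to compound 3

A few compounds are considered here, and "the series" means these few. Any claim that something is new, unique, unknown or untested is made for them only; others in the source may bear on it.

For the measured compounds named here, compound 1 `C/C=C/C(=O)N(Cc1ccc(OC)c(Br)c1)c1cc(OC)c(OC)c(OC)c1` carries the only number among the values shown in a functional assay on KYSE-450 cells (Homo sapiens) for inhibition, read by MTT assay, with a stated time of 48 h (on this read-out lower numbers stand for stronger inhibition and higher numbers for weaker inhibition), where compound 1 gives 10500 nM. Compound 2 `COc1cc(NCc2ccccc2)cc(OC)c1OC` shows only a limit in this assay, namely > 80000 nM. Going by the values given here, no step between two measured compounds is available to calibrate the size of any change. Compound 3 `C/C=C/C(=O)N(Cc1ccc(OC)c(O)c1)c1cc(OC)c(OC)c(OC)c1` differs from compound 1 by hydroxy in place of bromo on an aromatic carbon, read one bond further out as 3-bromo-4-methoxyphenyl to 3-hydroxy-4-methoxyphenyl. The expected step is small, a 1.3-fold lower number from compound 1 to compound 3 (0.12 log units; within the scatter), leaning toward stronger inhibition if anything. Compound 3 is estimated at 8000 nM, ranging from 2500 nM to 30000 nM.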

Compound 3, half-maximal inhibitory concentration: 67 nM
For compound 3 the middle estimate is 120-fold (2.08 log units) above the measured one; measured number below the stated range.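

Hydroxy in place of bromo on an aromatic carbon, ortho to a methoxy group, gives in this assay a 160-fold lower number from compound 1 to compound 3 (2.20 log units; beyond the scatter). This place on the ring therefore responds strongly to the exchange of one heavy atom, which compound 1 alone could not show. Nothing measured here accounts for the size of this step.

From the compounds shown here alone, whether the hydroxy itself is required remains open, since an amine or a fluoro at this place would test that. Going by these compounds, whether the step carries over to other cores also remains open.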